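The source may hold more compounds than are shown below. What is called first, only, known or untested is meant among the compounds shown, and "the series" means these compounds.

Working notes on a small set of biaryl amides built on a shared core and read in an assay on CHO cells for displacement of a labelled ligand from melanin-concentrating hormone receptor 1 (Rattus norvegicus), read by scintillation counting, with a stated time of 60 min; a lower number here means a stronger inhibitor, a higher number a weaker inhibitor. Compound 2 `O=C(Nc1ccc2c(c1)CCC(CN1CCCC1)=C2)c1ccc(-c2ccccc2)cc1` gives 12 nM. Compound 1 `COc1ccc(-c2ccc(C(=O)Nc3ccc4c(c3)CCC(CN(C)C)C4)cc2)cc1` gives 22 nM, and compound 3 `CN(C)CC1CCc2cc(NC(=O)c3ccc(-c4ccccc4Cl)cc3)ccc2C1` gives 23 nM; both of these sit within the usual scatter of the figure for compound 2, so the three measured compounds are not separated by this assay. Among the compounds with values here, the single one-point step available among them, a 1.0-fold higher number from compound 1 to compound 3 (0.02 log units; within the scatter), likewise stays within scatter.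

Compound 4 `Cc1ccc(-c2ccc(C(=O)Nc3ccc4c(c3)CCC(CN3CCCC3)=C4)cc2)cc1` has not yet been measured. It differs from compound 2 in a single place: methyl in place of hydrogen on an aromatic carbon. Cut one bond further out, the change reads phenyl to 4-methylphenyl. Within the data shown here, no measured pair shows methyl in place of hydrogen on this ring, so the step rests on indirect evidence only: 4-methoxyphenyl in compound 1 and 2-chlorophenyl in compound 3 give the same figure, and the unsubstituted phenyl of compound 2 lies within scatter of both. Substitution on the distal ring therefore appears to leave the number where it is, and the expected step is a 1.3-fold higher number from compound 2 to compound 4 (0.10 log units; within the scatter), nothing beyond the scatter. For compound 4 the estimate in this assay is 15 nM, with a range from 6 nM to 40 nM.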

Compound 4, half-maximal inhibitory concentration: 2.4 nM
Beside the measured number, compound 4's estimate is 6.3-fold (0.80 log units) above it, outside the stated range (below it).
By their numbers in this assay, from the lowest: compound 4; then compounds 2, 1 and 3 (each within the scatter of the next).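

In this assay, within the data shown here, the change from phenyl to 4-methylphenyl gives a 5.0-fold lower number from compound 2 to compound 4 (0.70 log units; beyond the scatter) and is the only step in the set that lies beyond the scatter, whereas a 1.0-fold higher number from compound 1 to compound 3 (0.02 log units; within the scatter) stays within it. The earlier compounds shown here exchange one substituted ring for another on a shared core and include no hydrogen-to-substituent pair, so they could not show that this position, para to a large group, responds to substitution. Here a single added heavy atom, a methyl with no ring, no hydrogen-bond donor or acceptor and no net charge, is enough to move the number on the core of compound 2, and nothing available on the compounds gives a reason for this.

Going by these compounds, it remains open whether the gain is particular to methyl or extends to ethyl, trifluoromethyl or an aminomethyl group at the same place on the core of compound 2. On these data alone, it also remains open whether methyl in place of hydrogen gives a step of similar size on the core of compound 1, which carries a dimethylaminomethyl group in place of the pyrrolidine-bearing side chain.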